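Working notes: a chloro step in a small series

A few compounds are considered here, and "the series" means these few. Any claim that something is new, unique, unknown or untested is made for them only; others in the source may bear on it.

Of the compounds shown here, two that share one core have been measured so far. In a physicochemical assay for solubility, read by nephelometry (on this read-out lower numbers stand for lower solubility and higher numbers for higher solubility), compound 1 `CCCCSc1nc(N)c2ncn(Cc3cc([N+](=O)[O-])ccc3OC)c2n1` gives 25000 nM. In this assay compound 2 `CCCCSc1nc(N)c2ncn(Cc3c(F)cccc3F)c2n1` gives 50000 nM. These two values lie within the usual scatter of each other, so the numbers shown do not separate compound 2 from compound 1. The two structures also differ in more than one place, and no single-change step can be read from them.

Compound 3 `CCCCSc1nc(N)c2ncn(Cc3c(F)ccc(Cl)c3F)c2n1` departs from compound 2 in one place. The change is chloro in place of hydrogen on an aromatic carbon, with chloro in place of hydrogen on an aromatic carbon, ortho to a fluoro group and para to a fluoro group. Within the data shown here, no measured pair shows this change, so the expectation is a judgement and not a read-across. A modest downward step in this assay is expected, and it may not clear the scatter. The expected size is a 2.0-fold lower number from compound 2 to compound 3 (0.30 log units; within the scatter). In this assay the estimate for compound 3 is 25000 nM, with an expected range from 9000 nM to 50000 nM.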

Compound 3, solubility: 25000 nM
Compound 3: middle estimate and measured number agree at the digits printed, within the range that was stated.
By their numbers in this assay, from the lowest: compounds 1, 3 and 2 (each within the scatter of the next).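

The series now holds its first single-change step: in this assay, chloro in place of hydrogen on an aromatic carbon, ortho to a fluoro group and para to a fluoro group, gives (a 2.0-fold lower number from compound 2 to compound 3 (0.30 log units; within the scatter)). At this position, on this background, adding one chlorine atom therefore leaves compound 3 and compound 2 unseparated by this read-out, which is more specific than the earlier comparison of compound 1 and compound 2, where several differences were mixed together. No independent measurement bearing on the reason for this result is available, so the step stands only as an observation.

Going by these compounds, whether a different group at this position, such as an amine, a carboxylic acid or a longer chain, would give a step beyond the scatter remains open, as does whether chloro would behave in the same way on a ring without the two fluoro groups. Compound 1 differs from compound 2 and from compound 3 in more than one place, so no single-change step can be read from those pairs, and one step on one background supports no general rule for the series.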